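A few compounds are considered here, and "the series" means these few. Any claim that something is new, unique, unknown or untested is made for them only; others in the source may bear on it.

Measured compounds in an ADME assay on Huh-7 cells (Homo sapiens) for cytotoxicity; on this read-out higher numbers stand for lower toxicity in this test and lower numbers for higher toxicity in this test:

- Compound 1 `Cc1ccccc1-c1nn(-c2ccc(Br)cc2)cc1CNCCN1CCN(C)CC1` gives 9600 nM in this assay.
- Compound 2 `CN1CCN(CCNCc2cn(-c3ccc(C(F)(F)F)cc3)nc2-c2ccc(C(F)(F)F)cc2)CC1` gives 1500 nM in this assay.
- Compound 3 `CN1CCN(CCNCc2cn(-c3ccc(F)cc3F)nc2-c2ccccc2)CC1` returns only a limit, > 20000 nM, in this assay.

Among the two compounds with a number in this assay, compound 1 stands highest, and the gap down to compound 2 lies beyond the scatter. The value of compound 3 is a limit of the assay and not a number; it is the limit of > 20000 nM in this assay, at which 1 of the 3 values shown sits, so compound 3 contributes no figure to compare against compound 1.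

The next compound, compound 4 `Cc1ccccc1-c1nn(-c2ccc([N+](=O)[O-])cc2)cc1CNCCN1CCN(C)CC1`, keeps the core of compound 1 and changes one place: nitro in place of bromo on an aromatic carbon. For the measured compounds named here, no pair of measured compounds differs by a single change, so no measured step is available as a guide for this exchange. With so little to rest on, the working expectation is that the exchange moves the number in this assay by no more than the scatter, if at all, in either direction.

Estimated for compound 4 in this assay: 10000 nM, within a range of 4000 nM to 25000 nM, which corresponds to an expected step of a 1.0-fold higher number from compound 1 to compound 4 (0.02 log units; within the scatter).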

Compound 4, half-maximal cytotoxic concentration: > 20000 nM
Compound 4: no number, only a limit; the forecaster's own chance of this, stated with the estimate: 25%; middle value at least 2.0-fold (0.30 log units) from the limit.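

In this assay, the change from 4-bromophenyl to 4-nitrophenyl gives an at least 2.0-fold higher number from compound 1 to compound 4 (0.31 log units; beyond the scatter). For the compounds shown here, this is the first step that differs in one place only, and it shows that the group on an aromatic carbon, para to a large group, is not silent in this read-out. The value of compound 4 is a limit of the assay and not a number, and compound 4 now shares that limit with compound 3: the limit of > 20000 nM in this assay, at which 2 of the 4 values shown sit.

Going by these compounds, with the core of compound 1 held fixed, it remains open where an amine, a nitrile or a methoxy group at this position would fall relative to bromo and nitro. On these data alone, compound 2 and compound 3 differ from compound 1 in more than one place, so whether the same exchange gives a step of this kind on another core also remains open.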